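From Cyclopentyl to Isopentyl: Compound 3 to Compound 4

The source may report more compounds than this note shows. Statements on the series, on what has been measured and on what is new or still open speak of the compounds shown alone.

Three compounds have been measured in a functional assay on Beta-TC3 cells (Rattus norvegicus) with Beta-TC3 (Mus musculus) as the target, using a membrane potential dye; a higher number here means a weaker inhibitor, a lower number a stronger inhibitor:

Compound 1 `N#CN/C(=N\C1CCCC1)Nc1cc(Cl)cc(Cl)c1` gives 12000 nM
Compound 2 `C[C@H](/N=C(\NC#N)Nc1cc(Cl)cc(Cl)c1)c1ccccc1` gives 25000 nM
Compound 3 `N#CN/C(=N\C1CCCC1)Nc1cc(C(F)(F)F)cc(C(F)(F)F)c1` gives 4700 nM

Compound 3 has the lowest number of the three, which in this read-out means the strongest inhibition. Compound 1, the nearest of the other two, gives a higher number, and the gap lies beyond the usual scatter of repeated measurements. Compound 2 gives a higher number still, and that gap too lies beyond the scatter. Among these three, compound 3 is therefore the most potent.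

Compound 4 `CC(C)CC/N=C(\NC#N)Nc1cc(C(F)(F)F)cc(C(F)(F)F)c1` is the next compound and has not yet been measured. It differs from compound 3 in one place: isopentyl in place of cyclopentyl on a double-bonded nitrogen. The group that leaves and the group that enters have the same number of heavy atoms; the difference is that the ring is opened into a branched chain. Within the data shown here, no pair of measured compounds shows what such an exchange does in this assay, so there is no measured step to lean on.

In the absence of such a step, a change of this size is expected to move the number little, if at all, beyond the scatter. Compound 4 is estimated to give 5500 nM, with a range from 2000 nM to 15000 nM. The expected step is a 1.2-fold higher number from compound 3 to compound 4 (0.07 log units; within the scatter).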

Compound 4, half-maximal inhibitory concentration: 4700 nM
Estimate against measurement, compound 4: 1.2-fold (0.07 log units) above; low and high end bracket the measured number.
By their numbers in this assay, from the lowest: compounds 3 and 4 (each within the scatter of the next); then compound 1; then compound 2.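

In this assay, among these compounds, replacing cyclopentyl with isopentyl on a double-bonded nitrogen brings no change at the digits printed from compound 3 to compound 4 (within the scatter), the first single-place change that can be read directly. At this position and on this core, the closed ring is therefore not needed to keep the inhibition seen with compound 3: an open, branched chain with the same count of 5 carbon atoms serves equally well in this one pair. No measurement is available to explain why the number stays where it is.

One pair cannot show whether the same exchange would behave alike on the core of compound 1, which carries chlorine atoms where compounds 3 and 4 carry trifluoromethyl groups. Also open, on these data alone, is how much room this position allows beyond groups of this count, for example with a shorter chain such as ethyl, a longer chain such as n-octyl, or a chain ending in an amine or a carboxylic acid.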